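Swapping 4-Carboxyphenyl for 3-Acetylphenyl on the Shared Core

This account rests on a few compounds, and the source may have more. Where it says the series, first, only, none or still open, it means among the compounds named here.

Of the compounds shown here, three built on a shared core have been measured in a functional assay on UACC-62 cells (Homo sapiens) for inhibition, read by sulforhodamine B assay, with a stated time of 48 h, tested at 10 uM; a lower number here means less inhibition of growth, a higher number more inhibition of growth at the concentration tested. In this series, compound 1 `CC(=O)c1ccc(Nc2ccnc(SCC(=O)c3ccc(Br)cc3)n2)cc1` gives 23%, compound 2 `CCOC(=O)c1ccc(Nc2ccnc(SCC(=O)c3ccc([N+](=O)[O-])cc3)n2)cc1` gives 29%, and compound 3 `O=C(O)c1ccc(Nc2ccnc(SCC(=O)c3ccc(C(F)(F)F)cc3)n2)cc1` gives 12%. Compound 3 therefore stands lowest of the three, and its gaps to both compound 1 and compound 2 lie beyond the usual scatter.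

The next compound is compound 4 `CC(=O)c1cccc(Nc2ccnc(SCC(=O)c3ccc(C(F)(F)F)cc3)n2)c1`. Its structure departs from that of compound 3 in one place: 3-acetylphenyl in place of 4-carboxyphenyl on a nitrogen on an aromatic ring, (3-acetylphenyl in place of 4-carboxyphenyl on a nitrogen on an aromatic ring).

Among the measured compounds shown here, no measured pair differs in one place only, so the size of this step cannot be read directly from the data. For the measured compounds named here, no measured compound carries the 3-acetylphenyl group either. The closest guide is compound 1, which also has an acetylphenyl group on that nitrogen and gives 23%, although it differs from compound 4 elsewhere as well. An upward step is therefore expected, modest in size and only slightly beyond the scatter, and it is estimated as a number 12 percentage points higher from compound 3 to compound 4 (beyond the scatter). For compound 4, the expected value in this assay is 24%, with an estimated range from 8% to 44%.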

Compound 4, percent growth inhibition at one concentration: 29%
For compound 4 the middle estimate is 5 percentage points below the measured one; low and high end bracket the measured number.
By their numbers in this assay, from the lowest: compound 3; then compounds 1, 2 and 4 (each within the scatter of the next).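

In this assay, among the compounds shown here, the exchange of 4-carboxyphenyl for 3-acetylphenyl on a nitrogen on an aromatic ring gives a number 17 percentage points higher from compound 3 to compound 4 (beyond the scatter), the first step that can be read with only one place changed. It shows that the readout responds to what sits on this nitrogen while the rest of the structure, including the trifluoromethyl-bearing part, stays the same, yet the step bundles several differences: a carboxylic acid gives way to an acetyl group, the count of hydrogen-bond donors in the group falls from one to none, and the names of the two groups show that the attachment number changes as well. No measurement at hand accounts for the size or direction of this step.

The compounds shown leave open whether the rise goes with the loss of the carboxylic acid, with the acetyl group itself, or with the change from 4 to 3 in the name, a question that 4-acetylphenyl or 3-carboxyphenyl on the same structure would bear on. As far as these compounds go, how an amide or an amine on that phenyl ring would read here also stays open.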